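The source may hold more compounds than are shown below. What is called first, only, known or untested is meant among the compounds shown, and "the series" means these compounds.

Working notes on the series. Compound 1 `COc1cc(C(=O)O)ccc1OCCCCOc1ccc(C(=O)CC(C)C)c(O)c1C` gives 85.7% in an assay on HEK293 cells for positive allosteric modulation of metabotropic glutamate receptor 2 (Rattus norvegicus), read by thallium flux, with a stated time of 2.5 min; on this read-out higher numbers stand for larger maximal responses and lower numbers for smaller maximal responses. Within the data shown here, compound 2 `Cc1c(OCCCCOc2ccc(C(=O)O)cc2F)ccc(C(=O)CC(C)C)c1O` gives 85% in this assay; the single step from compound 1 to compound 2, fluoro in place of methoxy on an aromatic carbon, came to a number 0.7 percentage points lower from compound 1 to compound 2 (within the scatter). Among the measured compounds shown here, on the two numbers measured, compound 2 therefore stands within the scatter of compound 1, the only other compound measured, so no order between them can be read.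

Compound 3 `Cc1cc(OCCCCOc2ccc(C(=O)CC(C)C)c(O)c2C)ccc1C(=O)O` has not yet been measured. It differs from compound 2 by 4-carboxy-3-methylphenyl in place of 4-carboxy-2-fluorophenyl on an oxygen on a saturated carbon. For the measured compounds named here, only one measured step, that from compound 1 to compound 2, touches this aromatic ring, and it was within the scatter; no step exchanges a fluorine for a methyl group on this ring. Given that the one step bearing on this ring, a number 0.7 percentage points lower from compound 1 to compound 2 (within the scatter), lay within the scatter, the maximal response of compound 3 is expected to stay near that of compound 2, with an expected step of a number 1 percentage points lower from compound 2 to compound 3 (within the scatter). Compound 3 is estimated at 84% in this assay, in a range from 70% to 96%.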

Compound 3, largest response reached (reported as percent of maximum), in percent of the reference or control that the assay uses: 93.3%
Estimate against measurement, compound 3: 9.3 percentage points below; the measured number falls inside the stated range.
By their numbers in this assay, from the lowest: compounds 2, 1 and 3 (each within the scatter of the next).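

In this assay, the exchange of 4-carboxy-2-fluorophenyl for 4-carboxy-3-methylphenyl on an oxygen on a saturated carbon gives a number 8.3 percentage points higher from compound 2 to compound 3 (within the scatter), so a methyl substituent on this ring also leaves the maximal response within the scatter. The earlier step covered only methoxy and fluoro; across methoxy, fluoro and methyl, all on a ring that keeps its carboxy group, no order can be read from the steps. No measurement offered here accounts for the size of this step.

As far as these compounds go, whether the response holds with a primary amide or a tetrazole in place of the carboxylic acid stays open. So does the effect of a chlorine or trifluoromethyl on this ring, or of a longer chain between the two ether oxygens.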